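Swapping halogens on the benzyl arm of a shared core

A few compounds are considered here, and "the series" means these few. Any claim that something is new, unique, unknown or untested is made for them only; others in the source may bear on it.

Within the data shown here, in a functional assay on CCRF-CEM cells (Homo sapiens) for antiproliferative activity, with a stated time of 72 h (a lower number here means a stronger inhibitor, a higher number a weaker inhibitor), compound 1 `OC[C@H]1O[C@@H](n2cnc3c(NCc4ccccc4F)ncnc32)[C@H](O)[C@@H]1O` gives 4600 nM, the lowest of the three numbers measured so far. Compound 2 `OC[C@H]1O[C@@H](n2cnc3c(NCc4ccc(Cl)cc4)ncnc32)[C@H](O)[C@@H]1O` gives 10200 nM in this assay, and compound 3 `OC[C@H]1O[C@@H](n2cnc3c(NCc4ccc(Br)cc4)ncnc32)[C@H](O)[C@@H]1O` gives 20600 nM. The step of a 2.2-fold higher number from compound 1 to compound 2 (0.35 log units; beyond the scatter) and the step of a 4.5-fold higher number from compound 1 to compound 3 (0.65 log units; beyond the scatter) both weaken the inhibitor, and the step of a 2.0-fold higher number from compound 2 to compound 3 (0.31 log units; beyond the scatter) shows that bromo costs a little more than chloro.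

Compound 4 `OC[C@H]1O[C@@H](n2cnc3c(NCc4ccc(Cl)cc4Cl)ncnc32)[C@H](O)[C@@H]1O` has not been measured in this assay. It differs from compound 1 by 2,4-dichlorophenyl in place of 2-fluorophenyl on a saturated chain carbon bound to a nitrogen on an aromatic ring. The steps to compound 2 and compound 3 bear on this change, since both replace the 2-fluorophenyl of compound 1 with a halogen-bearing phenyl and both lose potency by a modest amount. Among the measured compounds shown here, compound 4 carries the chloro seen in compound 2 together with a second chloro, so the measured steps cover the change only in part; the extra chloro has no direct precedent here.

On that basis compound 4 is expected to be somewhat weaker than compound 1, with a step of about a 1.8-fold higher number from compound 1 to compound 4 (0.27 log units; within the scatter). The estimate for compound 4 in this assay is 8500 nM, with a likely range from 3500 nM to 20000 nM.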

Compound 4, half-maximal inhibitory concentration: 86700 nM
Estimate against measurement, compound 4: 10-fold (1.01 log units) below; measured number outside the range, above it.
By their numbers in this assay, from the lowest: compound 1; then compound 2; then compound 3; then compound 4.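

The second chloro is the real news at this position: going to the 2,4-dichlorophenyl arm gives an 8.5-fold higher number from compound 2 to compound 4 (0.93 log units; beyond the scatter) in this assay, a far bigger penalty than the swap of one halogen for another seen earlier, a 2.0-fold higher number from compound 2 to compound 3 (0.31 log units; beyond the scatter). Among these compounds, measured against the best compound so far, the change gives a 19-fold higher number from compound 1 to compound 4 (1.28 log units; beyond the scatter), the only step in this small set large enough to take activity nearly out of reach, so the benzyl arm tolerates single halogens far better than this double substitution. The step of a 4.2-fold higher number from compound 3 to compound 4 (0.62 log units; beyond the scatter) adds that the 2,4-dichlorophenyl arm also falls behind the 4-bromophenyl arm, so the loss does not simply follow the heavier single halogen, and nothing available here explains why the added chloro costs so much.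

The compounds shown leave open whether the loss comes from carrying two halogens at all or from this particular pattern, and a 2-chlorophenyl arm on the shared core would help separate those two readings. A methoxy group or an amine on the same ring would show whether anything other than a halogen is accepted on this arm.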